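From Pyrimidin-2-yl to Pyrazin-2-yl on a Shared Core

A few compounds are considered here, and "the series" means these few. Any claim that something is new, unique, unknown or untested is made for them only; others in the source may bear on it.

In an ADME assay on the whole organism (plasma, strain 129/SvEvBrd x C57BL/6) for pharmacokinetics, with Mus musculus as the target, at a dose of 10 mg/kg by the oral route (a lower number here means less compound in the circulation, a higher number more compound in the circulation at the dose given), compound 1 `Cc1nc(-c2nc([C@@H](O)[C@H](O)[C@H](O)CO)c[nH]2)cs1` gives 1970 ng.h/mL and compound 2 `OC[C@@H](O)[C@@H](O)[C@H](O)c1c[nH]c(-c2ncccn2)n1` gives 799 ng.h/mL, which makes compound 2 the lower of the two measured compounds. Among the measured compounds shown here, the only measured step, a 2.5-fold lower number from compound 1 to compound 2 (0.39 log units; beyond the scatter), is modest and accompanies pyrimidin-2-yl in place of 2-methyl-1,3-thiazol-4-yl on an aromatic carbon. Compound 3 `OC[C@@H](O)[C@@H](O)[C@H](O)c1c[nH]c(-c2cnccn2)n1` keeps the shared core, and its change is pyrazin-2-yl in place of pyrimidin-2-yl on an aromatic carbon. For the measured compounds named here, no measured step covers this exchange, so the step to compound 1 gives only a rough guide to size. The leaving and entering groups match in every count, unlike those of that earlier step, so no shift beyond the scatter is expected in this assay. The estimated step is a 1.1-fold higher number from compound 2 to compound 3 (0.03 log units; within the scatter). For compound 3 the expected value is 850 ng.h/mL, with an estimated range of 380 ng.h/mL to 1900 ng.h/mL.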

Compound 3, area under the concentration-time curve: 1250 ng.h/mL
Compound 3: the middle estimate sits 1.5-fold (0.17 log units) below what was measured; the measured number falls inside the stated range.
By their numbers in this assay, from the lowest: compounds 2, 3 and 1 (each within the scatter of the next, the first and the last beyond it).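

In this assay, putting pyrazin-2-yl in place of pyrimidin-2-yl on this aromatic carbon gives a 1.6-fold higher number from compound 2 to compound 3 (0.19 log units; within the scatter), so exchanging these two groups, which have the same atoms joined differently, is not resolved from the scatter. Replacing 2-methyl-1,3-thiazol-4-yl with pyrazin-2-yl gives a 1.6-fold lower number from compound 1 to compound 3 (0.20 log units; within the scatter), whereas the earlier step to pyrimidin-2-yl, a 2.5-fold lower number from compound 1 to compound 2 (0.39 log units; beyond the scatter), lay beyond the scatter, so that earlier separation does not extend to every six-membered ring with 2 nitrogen at this position. No supporting measurement offers an explanation for these numbers.

The compounds shown leave open how pyridin-2-yl, with its single ring nitrogen, would compare at this position. They also leave open what a methyl group or an amine on the pyrazin-2-yl ring would do to the number in this assay.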